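This account rests on a few compounds, and the source may have more. Where it says the series, first, only, none or still open, it means among the compounds named here.

Working notes on the series. In a functional assay on MCF7 cells (Homo sapiens) for inhibition, read by radiometric assay and XTT assay (a higher number here means a weaker inhibitor, a lower number a stronger inhibitor), compound 1 `C/C=C/C(C)=C/[C@@]1(C)SC(O)=CC1=O` gives > 80 ug/mL, which is a limit and not a number. Compound 2 `CCCCCC[C@@]1(C)SC(O)=CC1=O` gives > 80 ug/mL, again a limit. Among the compounds with values here, compound 3 `CCCCCCCC[C@@]1(C)SC(O)=CC1=O` gives 17.6 ug/mL, the only actual number among the three.

The next structure, compound 4 `C=CCC1=C(O)S[C@](C)(CCCCCCCC)C1=O`, differs from compound 3 by allyl in place of hydrogen on a double-bonded ring carbon. The allyl sits next to the ring atom that bears a hydroxy group.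

Within the data shown here, only one measured step is available, an at least 4.5-fold lower number from compound 2 to compound 3 (0.65 log units; beyond the scatter). Among the measured compounds shown here, it lies on the saturated chain, beyond the scatter, and no step has been measured at this ring carbon. It therefore bears on the new change only loosely, and its size is not carried over. In this assay, a step no larger than the scatter is expected, with a slightly lower number the more likely direction. The expected step is a 1.3-fold lower number from compound 3 to compound 4 (0.10 log units; within the scatter). For compound 4 the estimated value is 14 ug/mL, with an estimated range of 5 ug/mL to 45 ug/mL.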

Compound 4, half-maximal inhibitory concentration: 44.4 ug/mL
Estimate against measurement, compound 4: 3.2-fold (0.50 log units) below, within the range that was stated.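

Within the data shown here, this is the first reading at the double-bonded ring carbon next to the ring atom that bears a hydroxy group. In this assay, allyl in place of hydrogen there gives a 2.5-fold higher number from compound 3 to compound 4 (0.40 log units; beyond the scatter), so this change weakens inhibition where the earlier step on the saturated chain strengthened it. Compound 4 still gives a number and not a limit, so substitution at this carbon leaves inhibition readable, though the top of the readable range is not far off: the limit of > 80 ug/mL in this assay, at which 2 of the 4 values shown sit.

Going by these compounds, whether methyl, a longer chain or a carboxylic acid on this ring carbon would move the number the same way as allyl stays open. Also open, on these data alone, is how allyl at this carbon would read on compound 2, whose > 80 ug/mL is a limit.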